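The source may report more compounds than this note shows. Statements on the series, on what has been measured and on what is new or still open speak of the compounds shown alone.

Compound 1, with the structure `O=C(Nc1ccc(Oc2ccnc3[nH]ccc23)cc1)c1nn(-c2ccc(Cl)cc2)ccc1=O`, was tested in a functional assay on A549 cells (Homo sapiens) for cytotoxicity, read by MTT assay, with a stated time of 72 h (a lower number here means a stronger inhibitor, a higher number a weaker inhibitor), and gave 25100 nM. Compound 2, with the structure `O=C(Nc1ccc(Oc2ccnc3[nH]ccc23)c(F)c1)c1nn(-c2ccc(Cl)cc2)ccc1=O`, differs from it by a fluoro in place of hydrogen on an aromatic carbon. In this assay compound 2 reached only a limit of the assay, > 60000 nM, so no exact number exists for it. The step of an at least 2.3-fold higher number from compound 1 to compound 2 (0.37 log units; beyond the scatter) is therefore known only as a floor, because of the limit of > 60000 nM in this assay, at which 1 of the 2 values shown sits. Going by the values given here, of the two compounds measured so far, compound 2 is the weaker, sitting where the assay stops reporting.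

Compound 3, with the structure `O=C(Nc1ccc(Oc2ccnc3[nH]ccc23)c(F)c1)c1nn(-c2ccc(Br)cc2F)ccc1=O`, keeps the fluoro of compound 2 and alters the other end of the molecule: 4-bromo-2-fluorophenyl in place of 4-chlorophenyl on an aromatic nitrogen. Among the compounds with values here, no measured step touches this ring; the single step measured concerns a different part of the shared core, and it moved the number up to the limit. With compound 2 already at the limit, compound 3 is expected to give 70000 nM, with a likely range from 20000 nM to 250000 nM, and most probably to be reported again only as a limit. The step that the limit leaves unreadable from compound 2 to compound 3 is expected to stay within the usual scatter.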

Compound 3, half-maximal inhibitory concentration: 55700 nM
Beside the measured number, compound 3's estimate is 1.3-fold (0.10 log units) above it; the range from low to high includes it.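

Going by these compounds alone, the ring on the aromatic nitrogen changes here for the first time, and with 4-bromo-2-fluorophenyl in place of 4-chlorophenyl, compound 3 gives an exact reading in this assay, 55700 nM. Compound 2 remains at a limit of the assay, > 60000 nM, which is not an exact number. The change can therefore be read only as an at least 1.0-fold lower number from compound 2 to compound 3 (0.03 log units; that floor lies within the scatter), so it shows no step beyond the usual scatter, yet the true size of the step remains unknown: the limit of > 60000 nM in this assay, at which 1 of the 3 values shown sits.

The bromine and the added fluorine enter together in compound 3, so the compounds shown cannot separate what each contributes at this position. They also leave open how the number would respond if this phenyl ring carried an amine or a carboxylic acid, or if a longer chain such as a benzyl group stood on the aromatic nitrogen in its place.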